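A few compounds are considered here, and "the series" means these few. Any claim that something is new, unique, unknown or untested is made for them only; others in the source may bear on it.

Measured compounds in a functional assay on SMMC-7721 cells (Homo sapiens) for inhibition, read by MTT assay, with a stated time of 48 h; a higher number here means a weaker inhibitor, a lower number a stronger inhibitor:
compound 1 `COc1ccc(-c2cc(NC(=O)Nc3ccncc3)cc(C(F)(F)F)c2)cn1` gives > 300000 nM
compound 2 `O=C(Nc1ccncc1)Nc1cc(-c2cncnc2)cc(C(F)(F)F)c1` gives 3730 nM

The figure for compound 1 is a limit of the assay, not a number: the limit of > 300000 nM in this assay, at which 1 of the 3 values shown sits. From compound 1 to compound 2 the change is pyrimidin-5-yl in place of 6-methoxypyridin-3-yl on an aromatic carbon, and the step is an at least 80-fold lower number from compound 1 to compound 2 (1.90 log units; beyond the scatter).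

In this assay compound 3 `COc1ccc(-c2ccc(OC(F)(F)F)c(NC(=O)Nc3ccncc3)c2)cn1` gives "not determined" (no result reported), so no result is reported for it. How the core of compound 3 differs from the core of compound 1 is not broken down here. Compound 4 `O=C(Nc1ccncc1)Nc1cc(-c2cncnc2)ccc1OC(F)(F)F` is not yet measured. The change from compound 3 to compound 4 is pyrimidin-5-yl in place of 6-methoxypyridin-3-yl on an aromatic carbon. Around the place the two changes differ: in the first the carbon is meta to a trifluoromethyl group, in the second it is para to a trifluoromethoxy group, so this is the same kind of change, not the same change.

Compound 3 has no measured value, so the size of the step to compound 4 cannot be set beside the earlier one. The expectation for compound 4 rests instead on compound 2, which carries the same entering group and gives 3730 nM. Compound 4 is expected to give about 6000 nM, estimated to lie between 1000 nM and 60000 nM.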

Compound 4, half-maximal inhibitory concentration: 3990 nM
Compound 4: the middle estimate sits 1.5-fold (0.18 log units) above what was measured; the measured number falls inside the stated range.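

Among the compounds shown here, no step to compound 4 can be read, as compound 3 has no reported result in this assay and so offers nothing to compare with. Nothing shown here accounts for the result of compound 4. From the compounds shown here alone, whether pyrimidin-5-yl in place of 6-methoxypyridin-3-yl matters as much on the core of compound 3 as on the core of compound 1 stays open.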